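Notes on the step from compound 2 to compound 4

A few compounds are considered here, and "the series" means these few. Any claim that something is new, unique, unknown or untested is made for them only; others in the source may bear on it.

Values in a functional assay on HepG2 cells (Homo sapiens) for inhibition, read by MTT assay, with a stated time of 3 days; a higher number here means a weaker inhibitor, a lower number a stronger inhibitor:
- compound 1 `COc1cc(-c2nc3ccccc3s2)ccc1OCC(=O)NNC(=O)CN[C@@H](CS)C(=O)O`: 3120 nM
- compound 2 `COc1cc(-c2nc3ccccc3s2)ccc1OCC(=O)NNC(=O)CN[C@@H](CS(=O)(=O)O)C(=O)O`: 3690 nM
- compound 3 `CCOC(=O)[C@H](NCC(=O)NNC(=O)COc1ccc(-c2nc3ccccc3s2)cc1OC)[C@@H](C)CC`: 3970 nM

Compound 2 stands at 3690 nM, within the scatter of both other compounds. Compound 4 `CCOC(=O)[C@H](CS)N(CC(=O)NNC(=O)COc1ccc(-c2nc3ccccc3s2)cc1OC)C(C)=O` is not yet measured and differs from compound 2 as follows: acetyl(1-(ethoxycarbonyl)-2-sulfanylethyl)amino in place of (1-carboxy-2-sulfoethyl)amino on a saturated chain carbon bound to a carbonyl carbon. In words, acetyl(1-(ethoxycarbonyl)-2-sulfanylethyl)amino comes in place of (1-carboxy-2-sulfoethyl)amino on a saturated chain carbon bound to a carbonyl carbon.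

Among the measured compounds shown here, three measured steps bear on this. Sulfo in place of sulfanyl gave a 1.2-fold higher number from compound 1 to compound 2 (0.07 log units; within the scatter). The 1-(ethoxycarbonyl)-2-methylbutyl group on the amine nitrogen gave a 1.3-fold higher number from compound 1 to compound 3 (0.10 log units; within the scatter) and a 1.1-fold higher number from compound 2 to compound 3 (0.03 log units; within the scatter). For the measured compounds named here, the acetyl group has no measured counterpart, so the range is kept wide. With these steps all small, no step beyond the scatter is expected in this assay. The estimated step is a 1.1-fold lower number from compound 2 to compound 4 (0.02 log units; within the scatter). Compound 4 is expected at 3500 nM, with an estimated range of 1600 nM to 7500 nM.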

Compound 4, half-maximal inhibitory concentration: 3010 nM
Estimate against measurement, compound 4: 1.2-fold (0.07 log units) above, and the stated range covers the measured number.
By their numbers in this assay, from the lowest: compounds 4, 1, 2 and 3 (each within the scatter of the next).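

In this assay the entering acetyl(1-(ethoxycarbonyl)-2-sulfanylethyl)amino group gives a 1.2-fold lower number from compound 2 to compound 4 (0.09 log units; within the scatter) and a 1.3-fold lower number from compound 3 to compound 4 (0.12 log units; within the scatter) and a 1.0-fold lower number from compound 1 to compound 4 (0.02 log units; within the scatter) at this place. The earlier compounds shown here all kept a hydrogen on the amine nitrogen, so compound 4 adds the first acetyl there, and this change, on a saturated chain carbon bound to a carbonyl carbon, still stays within the scatter of all three neighbours. No available evidence bears on why the number holds across these groups.

The compounds shown do not separate the acetyl from the ethoxycarbonyl, since both enter together from compound 1 to compound 4. From the compounds shown here alone, a longer acyl chain in place of acetyl, or a benzoyl group on the same nitrogen, remains open, as does whether any group at this place can move the number beyond the scatter.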